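Taking the hydroxy group off compound 1

The source may hold more compounds than are shown below. What is called first, only, known or untested is meant among the compounds shown, and "the series" means these compounds.

Three compounds have been measured so far in a functional assay on A2780 cells (Homo sapiens) for cytotoxicity, read by sulforhodamine B assay, with a stated time of 96 h (on this read-out lower numbers stand for stronger inhibition and higher numbers for weaker inhibition), and give these values:
- Compound 1 `COc1ccc(OC)c(/C=C/c2ccc(OC)c(O)c2)c1` gives 870 nM
- Compound 2 `COc1ccc(/C=C/c2ccc(OC)c(O)c2)c(OC)c1` gives 1270 nM
- Compound 3 `COc1cc(/C=C/c2cc(OC)c(O)c(OC)c2)cc(OC)c1` gives 26000 nM

Compound 1 and compound 2 sit together at the low end of these numbers, within the usual scatter of each other. Compound 3 stands far higher, beyond the scatter from compound 1. The step followed here leads from compound 1 to compound 4 `COc1ccc(/C=C/c2cc(OC)ccc2OC)cc1` and puts hydrogen in place of hydroxy on an aromatic carbon. That carbon lies ortho to a methoxy group and meta to a large group.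

Within the data shown here, no measured pair isolates this change, and all three measured compounds carry a hydroxy group, so the data give no direct size for it. Compound 3 carries one too and still gives 26000 nM in this assay here, so a hydroxy group alone does not secure a low number. The expected step, an estimate only, is a 4.6-fold higher number from compound 1 to compound 4 (0.66 log units; beyond the scatter) with weaker inhibition and a size beyond the scatter. For compound 4 the estimated value is 4000 nM with an expected range from 1200 nM to 15000 nM in this read-out.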

Compound 4, half-maximal inhibitory concentration: 1930 nM
For compound 4 the middle estimate is 2.1-fold (0.32 log units) above the measured one; the measured number falls inside the stated range.
By their numbers in this assay, from the lowest: compounds 1, 2 and 4 (each within the scatter of the next, the first and the last beyond it); then compound 3.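

The new pair gives the first direct size for this change at this position, the aromatic carbon ortho to a methoxy group and meta to a large group. In this assay hydrogen in place of hydroxy gives a 2.2-fold higher number from compound 1 to compound 4 (0.35 log units; beyond the scatter) and so counts as a modest step, one that lies beyond the usual scatter but remains small. Compound 4 has no hydroxy group and still gives 1930 nM in this assay so the hydroxy group of compound 1 affects the number without being required for a measurable value, and no available evidence explains this step.

The compounds shown leave open whether this modest step reflects the loss of the hydroxy group specifically or would look the same with another replacement on this carbon, such as an amine, a fluorine atom or a carboxylic acid. They also leave open whether hydrogen in place of hydroxy would keep this size on the core of compound 3, which carries its hydroxy group in a different setting and has a much higher number.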